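The compounds below may be only part of what the source reports. "The series", "measured", "known", "first", "only" and "open" are said of these compounds alone.

Compound 1 `CCCC(=O)N1c2ccccc2CCC1C(=O)Nc1ccccc1C(F)(F)F`; compound 2 `O=C(Nc1ccccc1C(F)(F)F)C1CCc2ccccc2N1`.

In a functional assay on NCI-H23 cells (Homo sapiens) for cytotoxicity, read by sulforhodamine B assay, with a stated time of 72 h (on this read-out higher numbers stand for weaker inhibition of growth and lower numbers for stronger inhibition of growth), compound 1 gives only a limit of the assay, > 70000 nM. In this assay compound 2 gives 56800 nM, the only number shown. Compound 3 `CCC(=O)N1c2ccccc2CCC1C(=O)Nc1ccccc1C(F)(F)F` has not yet been measured. It differs from compound 2 by propanoyl in place of hydrogen on a nitrogen on an aromatic ring in a ring. Among the compounds with values here, the one step that bears on this is an at least 1.2-fold lower number from compound 1 to compound 2 (0.09 log units; that floor lies within the scatter), with compound 1 sitting at the limit of > 70000 nM in this assay, at which 1 of the 2 values shown sits. Restoring an acyl group on that nitrogen is therefore expected to leave the number within the scatter or push it toward the limit. Compound 3 is estimated at 75000 nM, between 40000 nM and 150000 nM. This estimate means an expected step of a 1.3-fold higher number from compound 2 to compound 3 (0.12 log units; within the scatter).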

Compound 3, concentration for 50% growth inhibition: > 80000 nM
Compound 3: no number, only a limit; the forecaster's own chance of this, stated with the estimate: 50%; middle value at least 1.0-fold (0.02 log units) away from the limit.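

Propanoyl in place of hydrogen on this nitrogen gives an at least 1.4-fold higher number from compound 2 to compound 3 (0.14 log units; that floor lies within the scatter), so the new compound does not show a change beyond the scatter. In this assay, within the data shown here, compound 3 gives only a limit, which leaves compound 2, with hydrogen on that nitrogen, as the only compound of the three with a number: the limit of > 80000 nM in this assay, at which 1 of the 3 values shown sits. The step between compound 1 and compound 3 cannot be read, as both values are limits.

Going by these compounds, whether acetyl or methyl on that nitrogen would give a number in this assay remains open. So does the effect of a carboxylic acid in place of trifluoromethyl.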